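A few compounds are considered here, and "the series" means these few. Any claim that something is new, unique, unknown or untested is made for them only; others in the source may bear on it.

Working notes on the series in an ADME assay on BJ cells (Homo sapiens) for cytotoxicity, with a stated time of 72 h; on this read-out higher numbers stand for an effect only at larger amounts of compound and lower numbers for an effect already at smaller amounts. Compound 1 `CCc1ccc(-c2nc3c(c(C)nn3-c3ccccc3)c(-c3ccccc3O)c2C#N)cc1` gives > 20000 nM, which is a limit of the assay and not a number. Compound 2 `Cc1ccccc1-c1nc2c(c(C)nn2-c2ccccc2)c(-c2ccccc2O)c1C#N` gives 21000 nM. Within the data shown here, compound 3 `CCCc1ccc(-c2nc3c(c(C)nn3-c3ccccc3)c(-c3ccccc3O)c2C#N)cc1` gives 22500 nM, which lies within the scatter of the only other readable number.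

Compound 4 `Cc1nn(-c2ccccc2)c2nc(-c3ccc(C#N)cc3)c(C#N)c(-c3ccccc3O)c12` differs from compound 3 at one place, with cyano in place of propyl on an aromatic carbon, para to a large group: cyano in place of propyl on an aromatic carbon. The same difference reads 4-propylphenyl to 4-cyanophenyl.

Two measured steps at this place give no size: a step that the limit leaves unreadable from compound 1 to compound 2 and a step that the limit leaves unreadable from compound 1 to compound 3. Among the measured compounds shown here, the only readable step there is a 1.1-fold higher number from compound 2 to compound 3 (0.03 log units; within the scatter). For the measured compounds named here, no measured step brings cyano into this place, so the basis is thin. In this assay, going by the values given here, no change beyond the scatter is expected, since the one readable exchange at this place, a 1.1-fold higher number from compound 2 to compound 3 (0.03 log units; within the scatter), stayed within it. The expected step is a 1.0-fold lower number from compound 3 to compound 4 (0.01 log units; within the scatter). For compound 4 the estimated value is 22000 nM, with an expected range of 11000 nM to 45000 nM.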

Compound 4, half-maximal effective concentration: > 20000 nM
Compound 4: no number, only a limit (the forecaster's own chance of this, stated with the estimate: 35%); the middle value does not contradict the limit.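

Compound 4 gives > 20000 nM, a limit of the assay and not a number, so no step to it from compound 1, compound 2 or compound 3 can be read: the limit of > 20000 nM in this assay, at which 2 of the 4 values shown sit.

On these data alone, whether cyano in place of propyl on an aromatic carbon moves the number beyond the scatter remains open.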